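A few compounds are considered here, and "the series" means these few. Any claim that something is new, unique, unknown or untested is made for them only; others in the source may bear on it.

Compound 1 `CCCCCCCCCCCCn1cc(COC[C@@H]2OC[C@H](N)[C@@H]2O)nn1`: 2210 nM
Compound 2 `CCCCCCCCCCCCCCn1cc(COC[C@@H]2OC[C@H](N)[C@@H]2O)nn1`: 1850 nM

In a functional assay on MCF7 cells (Homo sapiens) for antiproliferative activity, read by MTT assay, with a stated time of 48 h (on this read-out higher numbers stand for weaker inhibition and lower numbers for stronger inhibition), compound 2 gives 1850 nM. Among the measured compounds shown here, that places it within the usual scatter of compound 1, the only other compound measured, so the two cannot be ranked. The next compound, compound 3 `CCCCCCCCCCCCCCCCn1cc(COC[C@@H]2OC[C@H](N)[C@@H]2O)nn1`, has not yet been measured. It differs from compound 2 by one change: ethyl in place of hydrogen on a saturated chain carbon, ten or more bonds along the chain from an aromatic nitrogen. The same change has been measured once before, as a 1.2-fold lower number from compound 1 to compound 2 (0.08 log units; within the scatter). For the measured compounds named here, that single step is the only guide, and it does not show whether a further extension of the chain would behave alike. With nothing else to go on, no change beyond the scatter is expected in this assay. The expected step is a 1.0-fold lower number from compound 2 to compound 3 (0.01 log units; within the scatter). For compound 3 the estimated value is 1800 nM, with an expected range from 900 nM to 3800 nM.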

Compound 3, half-maximal inhibitory concentration: 3300 nM
Estimate against measurement, compound 3: 1.8-fold (0.26 log units) below; the measured number falls inside the stated range.
By their numbers in this assay, from the lowest: compounds 2, 1 and 3 (each within the scatter of the next).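

In this assay, repeating the change gives a 1.8-fold higher number from compound 2 to compound 3 (0.25 log units; within the scatter) and, read over both extensions together, butyl in place of hydrogen at this place gives a 1.5-fold higher number from compound 1 to compound 3 (0.17 log units; within the scatter) on the same scale. The earlier pair showed only one extension of the chain, whereas these steps show that neither a further ethyl nor the full butyl difference moves the number beyond the scatter, so the three chains cannot be ranked and no trend with chain length can be claimed. Nothing measured here bears on why the numbers fall where they do.

On these data alone, whether a much shorter chain or a longer chain would move the number beyond the scatter remains open. So does the effect of a carboxylic acid or an amine at the far end of the chain.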